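Pyrazol-3-yl replaces 4-hydroxyphenyl on the shared core

The source may report more compounds than this note shows. Statements on the series, on what has been measured and on what is new or still open speak of the compounds shown alone.

Measured so far:
Compound 1, `OC[C@H]1OC(n2cnc3c(-c4ccc(Cl)cc4)ncnc32)[C@H](O)[C@@H]1O`, in a functional assay on CCRF-CEM cells (Homo sapiens) for inhibition (a higher number here means a weaker inhibitor, a lower number a stronger inhibitor), compound 1 gives 900 nM.
Compound 2, `OC[C@H]1OC(n2cnc3c(-c4ccco4)ncnc32)[C@H](O)[C@@H]1O`, compound 2 gives 600 nM.
Compound 3, `OC[C@H]1OC(n2cnc3c(-c4ccc(O)cc4)ncnc32)[C@H](O)[C@@H]1O`, compound 3 gives 1250 nM.

Compound 3 carries the highest of the three numbers; the two steps that lead to it are a 1.4-fold higher number from compound 1 to compound 3 (0.14 log units; within the scatter) and a 2.1-fold higher number from compound 2 to compound 3 (0.32 log units; beyond the scatter). Compound 4, `OC[C@H]1OC(n2cnc3c(-c4cc[nH]n4)ncnc32)[C@H](O)[C@@H]1O`, differs from compound 3 in one place: 1H-pyrazol-3-yl in place of 4-hydroxyphenyl on an aromatic carbon. Within the data shown here, two steps bear on this change. The step of a 1.5-fold lower number from compound 1 to compound 2 (0.18 log units; within the scatter) exchanged a six-membered carbon ring for a five-membered heteroaromatic ring, and the step of a 2.1-fold higher number from compound 2 to compound 3 (0.32 log units; beyond the scatter) ran the other way. Compound 4 again brings a five-membered ring with hetero atoms, so a modest fall in the number is expected, a 1.8-fold lower number from compound 3 to compound 4 (0.25 log units; within the scatter). Compound 4 is therefore estimated at 700 nM, within 300 nM to 1600 nM.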

Compound 4, half-maximal inhibitory concentration: 750 nM
Compound 4: middle estimate off by 1.1-fold (0.03 log units), on the low side, and the stated range covers the measured number.
By their numbers in this assay, from the lowest: compounds 2, 4, 1 and 3 (each within the scatter of the next, the first and the last beyond it).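

In this assay, 1H-pyrazol-3-yl on this aromatic carbon cannot be told apart from any of the three earlier groups: the steps are a 1.7-fold lower number from compound 3 to compound 4 (0.22 log units; within the scatter) and a 1.3-fold higher number from compound 2 to compound 4 (0.10 log units; within the scatter) and a 1.2-fold lower number from compound 1 to compound 4 (0.08 log units; within the scatter). A five-membered aromatic ring with two nitrogens is therefore accepted here, with compound 4 falling within the scatter of both compound 2 and compound 3, although those two lie beyond the scatter of each other. No available evidence explains this result. Going by these compounds, whether an amine or a carboxylic acid at this position would shift the number beyond the scatter remains open.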